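Methyl for fluoro on the sulfonyl phenyl ring

The source may report more compounds than this note shows. Statements on the series, on what has been measured and on what is new or still open speak of the compounds shown alone.

Three compounds of the series have numbers in a functional assay on HCT-116 cells (Homo sapiens) for antiproliferative activity, read by MTT assay, with a stated time of 72 h; a higher number here means a weaker inhibitor, a lower number a stronger inhibitor. Compound 1 `COc1ncc(-c2ccc3nc(NC(=O)NCCN4CCCC4)sc3c2)cc1NS(=O)(=O)c1ccc(F)cc1` gives 310 nM. Compound 2 `CCN(CC)CCNC(=O)Nc1nc2ccc(-c3cnc(OC)c(NS(=O)(=O)c4ccc(F)cc4)c3)cc2s1` gives 300 nM, the lowest number of the three, although the step of a 1.0-fold lower number from compound 1 to compound 2 (0.01 log units; within the scatter) sits within the scatter, so compounds 1 and 2 are not separated. Compound 3 `COc1ncc(-c2ccc3nc(NC4CC4)sc3c2)cc1NS(=O)(=O)c1ccc(F)cc1` gives 1560 nM; the steps of a 5.0-fold higher number from compound 1 to compound 3 (0.70 log units; beyond the scatter) and a 5.2-fold higher number from compound 2 to compound 3 (0.72 log units; beyond the scatter) are modest and beyond the scatter.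

Compound 4 `CCN(CC)CCNC(=O)Nc1nc2ccc(-c3cnc(OC)c(NS(=O)(=O)c4ccc(C)cc4)c3)cc2s1` differs from compound 2 in one place: methyl in place of fluoro on an aromatic carbon. Among the compounds with values here, both measured steps change the group on a nitrogen on an aromatic ring; no measured pair varies the (4-fluorophenyl)sulfonyl group. Within the data shown here, the set therefore holds no step that bears directly on this change. With nothing pointing either way, the expectation for compound 4 is a step of a 1.1-fold higher number from compound 2 to compound 4 (0.03 log units; within the scatter) that stays within the scatter. The estimate for compound 4 is 320 nM, with a range from 130 nM to 800 nM.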

Compound 4, half-maximal inhibitory concentration: 180 nM
Compound 4: middle estimate off by 1.8-fold (0.25 log units), on the high side; low and high end bracket the measured number.
By their numbers in this assay, from the lowest: compounds 4, 2 and 1 (each within the scatter of the next); then compound 3.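

Within the data shown here, this is the first look at the (4-fluorophenyl)sulfonyl group: in this assay there is a 1.7-fold lower number from compound 2 to compound 4 (0.22 log units; within the scatter), so fluoro and methyl on this aromatic carbon, para to a large group, are not separated. Among these compounds, the position therefore accepts this single heavy-atom exchange with the (2-(diethylamino)ethyl)carbamoyl side of the molecule held constant, whereas the earlier steps spoke only to the group on the nitrogen on the aromatic ring. Nothing measured here explains how the two groups compare.

Still open, on these data alone, is whether a methoxy group, a chlorine, an amine or a carboxylic acid at this position would also stay close to compound 2. Also open, as far as these compounds go, is whether the same exchange gives a similar step with the pyrrolidin-1-yl chain of compound 1 or the cyclopropyl group of compound 3.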